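Chlorobenzyl ring substitution pattern in a nucleoside thioether series

This account rests on a few compounds, and the source may have more. Where it says the series, first, only, none or still open, it means among the compounds named here.

Two members of the series have been run in an assay on K562 cells for displacement of a labelled ligand from Equilibrative nucleoside transporter 1 (Homo sapiens); on this read-out lower numbers stand for stronger inhibition and higher numbers for weaker inhibition. Compound 1 `OC[C@H]1O[C@@H](n2cnc3c(SCc4ccccc4Br)ncnc32)[C@H](O)[C@@H]1O` gives 134 nM in this assay. Compound 2 `OC[C@H]1O[C@@H](n2cnc3c(SCc4cccc(Cl)c4)ncnc32)[C@H](O)[C@@H]1O` gives 16 nM in this assay. Going by the values given here, the single step among measured compounds, an 8.4-fold lower number from compound 1 to compound 2 (0.92 log units; beyond the scatter), is beyond the scatter. Among the compounds with values here, compound 2 thus stands at the lowest of the two numbers so far, its only neighbour being compound 1 on the far side of that step.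

Compound 3 `OC[C@H]1O[C@@H](n2cnc3c(SCc4ccc(Cl)cc4)ncnc32)[C@H](O)[C@@H]1O` has not yet been measured in this assay. It differs from compound 2 by 4-chlorophenyl in place of 3-chlorophenyl on a saturated chain carbon bound to a sulfur. Within the data shown here, the only measured step that bears on this change is the one from compound 1 to compound 2, and that step swapped both the halogen and its place on the ring at once; no measured pair moves a chlorine alone from one ring position to another. Nothing in the data therefore points to a direction, and the expected step of a 1.3-fold higher number from compound 2 to compound 3 (0.10 log units; within the scatter) from compound 2 to compound 3 is one not beyond the scatter. On this basis compound 3 is estimated at 20 nM in this assay, with a range of 6 nM to 70 nM to reflect the lack of a direct precedent.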

Compound 3, inhibition constant: 14.2 nM
Estimate against measurement, compound 3: 1.4-fold (0.15 log units) above, within the range that was stated.
By their numbers in this assay, from the lowest: compounds 3 and 2 (each within the scatter of the next); then compound 1.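

In this assay, going by these compounds alone, 4-chlorophenyl in place of 3-chlorophenyl on a saturated chain carbon bound to a sulfur gives a 1.1-fold lower number from compound 2 to compound 3 (0.05 log units; within the scatter) and is the first reading of a chlorine moved alone on this ring, with no separation between these two chlorine patterns on this read-out. The 4-chlorobenzyl compound also stands clear of the 2-bromophenyl compound, with a 9.4-fold lower number from compound 1 to compound 3 (0.97 log units; beyond the scatter) beyond the scatter, so compound 2 and compound 3 now lie on the same side of compound 1 and the earlier step no longer rests on a single chlorine pattern. No supporting data are available to account for these numbers.

Going by these compounds, whether the distance from compound 1 belongs to the bromine or to its place on the ring remains open, as the halogen and its place change together in both steps from that compound. Also open, on these data alone, is whether the flat reading between the two chlorine patterns would hold for an amine or a carboxylic acid on the ring in place of chlorine, or for a longer chain such as 2-phenylethyl in place of the benzyl group on sulfur.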